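This account rests on a few compounds, and the source may have more. Where it says the series, first, only, none or still open, it means among the compounds named here.

Two compounds of the series carry numbers. Compound 1, `CC[C@H](C)[C@H](NC(=O)N1CCC2(CC1)C(=O)N(c1cccc(F)c1)C2c1ccc(Cl)cc1)C(=O)OC`, gives in an assay on HEK293 cells for inhibition of Voltage-dependent T-type calcium channel subunit alpha-1H (Homo sapiens), read by patch clamp, using a membrane potential dye (on this read-out lower numbers stand for stronger inhibition and higher numbers for weaker inhibition), two entries, 45 nM; 872 nM (2 entries), which lie far apart from each other. Going by the values given here, compound 2, `CC[C@H](C)[C@H](NC(=O)N1CCC2(CC1)C(=O)N(c1cccc(F)c1)C2c1ccc(Cl)cc1)C(=O)NC`, gives in this assay 182 nM; it is the only compound of the series with a single number, and that number sits between the two entries of compound 1. The spread recorded for compound 1, (the several entries of compound 1 in this assay, 45 nM; 872 nM (2 entries)), is the only indication of how far repeated readings in this assay can wander. Compound 3, `COC(=O)[C@H](COC(C)(C)C)NC(=O)N1CCC2(CC1)C(=O)N(c1cccc(F)c1)C2c1ccc(Cl)cc1`, has not been measured in this assay. It differs from compound 2 in one place: 1-(methoxycarbonyl)-2-(tert-butoxy)ethyl in place of 2-methyl-1-(methylcarbamoyl)butyl on an amide-type nitrogen. The methylcarbamoyl group of compound 2 gives way to a methoxycarbonyl group, the ester form also present in compound 1, while the tert-butoxy arm replaces the branched alkyl side chain. Among the compounds with values here, no step between measured compounds exists that would show how such a change acts in this assay. The expected step is a 1.6-fold higher number from compound 2 to compound 3 (0.22 log units; within the scatter), a weakening that may well stay within the scatter. Compound 3 is expected to give 300 nM, within 60 nM to 1500 nM.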

Compound 3, half-maximal inhibitory concentration: 251 nM
Compound 3: the middle estimate sits 1.2-fold (0.08 log units) above what was measured, and the stated range covers the measured number.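

In this assay, going by these compounds alone, the first readable step concerns the substituent on the amide-type nitrogen: 1-(methoxycarbonyl)-2-(tert-butoxy)ethyl in place of 2-methyl-1-(methylcarbamoyl)butyl gives a 1.4-fold higher number from compound 2 to compound 3 (0.14 log units; within the scatter). At this position, therefore, a substituent with 11 heavy atoms, 0 hydrogen-bond donors, 3 hydrogen-bond acceptors and 1 defined stereocentre cannot be told apart from one with 9 heavy atoms, 1 hydrogen-bond donor, 1 hydrogen-bond acceptor and 2 defined stereocentres. The step is also small beside the spread recorded for a single compound of the series: the several entries of compound 1 in this assay, 45 nM; 872 nM (2 entries).

The exchange alters the carbonyl end and the side chain together, so the compounds shown cannot assign any share of the step to either part, and a pairing of the tert-butoxy arm with the methylcarbamoyl group would be needed to separate them. It also remains open how this read-out responds to a carboxylic acid in place of the methoxycarbonyl group or to a primary amine on the side chain, since both the ester and the amide shown here are neutral, uncharged substituents.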